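Removing a methyl from the ether oxygen in a pyrazole urea

The source may hold more compounds than are shown below. What is called first, only, known or untested is meant among the compounds shown, and "the series" means these compounds.

Measured compounds:
compound 1, `O=C(Nc1cccc(-n2cc(-c3ccncc3)c(-c3ccc(Cl)c(O)c3)n2)c1)Nc1cccc(C(F)(F)F)c1`, 6130 nM
compound 2, `COc1cc(-c2nn(-c3cccc(NC(=O)Nc4cc(C(F)(F)F)cc(C(F)(F)F)c4)c3)cc2-c2ccncc2)ccc1Cl`, 1230 nM

Of the compounds shown here, two have been measured in a functional assay on OVCAR-3 cells (Homo sapiens) for inhibition, read by sulforhodamine B assay, with a stated time of 48 h; a higher number here means a weaker inhibitor of growth, a lower number a stronger inhibitor of growth. Compound 2 gives 1230 nM, the lowest of the two numbers; compound 1 gives 6130 nM, a higher number that lies beyond the scatter of the method. The two compounds differ in more than one place, so their gap cannot be assigned to a single change.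

Compound 3, `O=C(Nc1cccc(-n2cc(-c3ccncc3)c(-c3ccc(Cl)c(O)c3)n2)c1)Nc1cc(C(F)(F)F)cc(C(F)(F)F)c1`, has not yet been measured in this assay. It arises from compound 2 by one change: hydrogen in place of methyl on an oxygen on an aromatic ring. Cut one bond further out, the change reads methoxy to hydroxy, and the aryl group goes from 4-chloro-3-methoxyphenyl to 4-chloro-3-hydroxyphenyl. For the measured compounds named here, no pair of measured compounds isolates this change, so its size is unknown from the data. The hydroxy form is present in compound 1, whose value in this assay is the higher one, but compound 1 also carries a different urea aryl group.

For compound 3 a modest shift toward a higher number is expected, with the step of a 1.8-fold higher number from compound 2 to compound 3 (0.25 log units; within the scatter) likely near or just beyond the scatter. The estimated value for compound 3 is 2200 nM, within a range of 700 nM to 7000 nM.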

Compound 3, concentration for total growth inhibition: 1200 nM
Compound 3: middle estimate off by 1.8-fold (0.26 log units), on the high side, within the range that was stated.
By their numbers in this assay, from the lowest: compounds 3 and 2 (each within the scatter of the next); then compound 1.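

In this assay, replacing methoxy with hydroxy on the oxygen on an aromatic ring gives a 1.0-fold lower number from compound 2 to compound 3 (0.01 log units; within the scatter), so with the urea aryl group of compound 2 held fixed, the methyl on this oxygen makes no difference that the measurement can resolve. The second step isolates the other part of the structure: with hydroxy held fixed, trifluoromethyl in place of hydrogen on an aromatic carbon gives a 5.1-fold lower number from compound 1 to compound 3 (0.71 log units; beyond the scatter), and this is the only single change shown that lies beyond the scatter. No measurement bearing on the reason for the size of either step is available here.

The compounds shown leave open whether methoxy and hydroxy would also match with the urea aryl group of compound 1, as no compound shown forms a methoxy partner to compound 1. They also leave open how a longer chain on this oxygen, such as ethoxy, or an amine in place of the hydroxy would read in this assay.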